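Bromo for iodo on a prostaglandin-like cyclopentenone scaffold

This account rests on a few compounds, and the source may have more. Where it says the series, first, only, none or still open, it means among the compounds named here.

Compound 1 `CCCCC/C=C\C[C@]1(O)C=CC(=O)/C1=C/C=C/CCCC(=O)OC` gives 5400 nM in a functional assay on PC-3 cells (Homo sapiens) for cytotoxicity, read by sulforhodamine B assay, with a stated time of 72 h; a lower number here means a stronger inhibitor, a higher number a weaker inhibitor.
Compound 2 `CCCCC/C=C\C[C@@]1(O)C=C(I)C(=O)/C1=C\C=C\CCCC(=O)OC` gives 6700 nM.
Compound 3 `CCCCC/C=C\C[C@]1(O)C=CC(=O)/C1=C\C=C\CCCC(=O)OC` gives 3900 nM.

Among the three measured compounds, compound 2 gives the highest number, yet its separation from compound 1 and from compound 3 is within the scatter, so the three cannot be ranked against one another. For the measured compounds named here, the only measured step that joins two compounds differing in a single place is a 1.4-fold lower number from compound 1 to compound 3 (0.14 log units; within the scatter), and that step rests on (the fact that compounds 1 and 3 differ only in the configuration as drawn); it concerns the configuration of a double bond, not a substituent on the ring, and it stays within the scatter.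

Compound 4 `CCCCC/C=C\C[C@@]1(O)C=C(Br)C(=O)/C1=C\C=C\CCCC(=O)OC` differs from compound 2 by bromo in place of iodo on a double-bonded ring carbon. Going by the values given here, no measured step involves a change of this kind, so nothing among the measured compounds speaks for or against a shift in either direction. The most defensible expectation is therefore that compound 4 stays close to compound 2, with any difference no larger than the scatter, which corresponds to an expected step of a 1.1-fold lower number from compound 2 to compound 4 (0.05 log units; within the scatter). Compound 4 is accordingly estimated at 6000 nM, with a range from 3000 nM to 12000 nM.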

Compound 4, half-maximal inhibitory concentration: 500 nM
Compound 4: the middle estimate sits 12-fold (1.08 log units) above what was measured; measured number below the stated range.
By their numbers in this assay, from the lowest: compound 4; then compounds 3, 1 and 2 (each within the scatter of the next).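

In this assay, for the compounds shown here, bromo in place of iodo on a double-bonded ring carbon of the five-membered ring produces a large step beyond the scatter (a 13-fold lower number from compound 2 to compound 4 (1.13 log units; beyond the scatter)), whereas the only earlier step concerned the configuration of a double bond and stayed within the scatter (a 1.4-fold lower number from compound 1 to compound 3 (0.14 log units; within the scatter)). This is the first sign among these compounds that the number responds strongly to a single change on the shared core, and that change sits on the ring carbon two ring bonds from the ring atom that bears a hydroxy group. The exchange replaces one heavy atom with one heavy atom and leaves the counts of hydrogen-bond donors and acceptors and the net charge as they were, and the one available fact about these compounds concerns only compounds 1 and 3, so nothing on record bears on the cause of this step.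

On these data alone, whether chloro or fluoro on the same ring carbon would extend the step seen from iodo to bromo remains open, as does the effect of a methyl group there. As far as these compounds go, it is also open whether bromo would give a step of similar size on the core of compound 1, with its double bond drawn the other way.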